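Cytotoxicity notes on the amide series, compound 3 to 4

The source may hold more compounds than are shown below. What is called first, only, known or untested is meant among the compounds shown, and "the series" means these compounds.

Three analogues of a shared core have been examined in an ADME assay on HepG2 2.2.15 cells (Homo sapiens) for cytotoxicity; a lower number here means that less compound is tolerated, a higher number that more compound is tolerated. Compound 1 `CC(C)(C)OC(=O)Nc1ncc(C(Oc2ccc3cc(Br)ccc3c2)c2ccc(Cl)cc2)s1` reaches only the ceiling of the assay. In this assay compound 1 gives > 50000 nM, which is a limit and not a number. Compound 2 `CC(C)(C)C(=O)Nc1ncc(C(Oc2ccc3cc(Br)ccc3c2)c2ccc(Cl)cc2)s1` is entered in this assay as "not toxic" (no number reported). Compound 3 `O=C(Nc1ncc(C(Oc2ccc3cc(Br)ccc3c2)c2ccc(Cl)cc2)s1)C1CCOCC1` is likewise entered in this assay as "not toxic" (no number reported). Compound 3 thus stands without a single number; among the three values shown, one sits at the limit of > 50000 nM in this assay, at which 1 of the 3 values shown sits, and the other two carry no number at all. Compound 4 `O=C(Nc1ncc(C(Oc2ccc3cc(Br)ccc3c2)c2ccc(Cl)cc2)s1)c1ccc(F)cc1` differs from compound 3 in one place: 4-fluorophenyl in place of oxan-4-yl on a carbonyl carbon. For the measured compounds named here, no step between measured compounds is available, so the size of this change in this assay cannot be read from the series; with no compound in the set showing a measurable toxicity, no step beyond the scatter is expected in either direction. Compound 4 is therefore expected to give about 50000 nM in this assay, within 20000 nM to 120000 nM, most likely reported again only as a limit.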

Compound 4, half-maximal cytotoxic concentration: "not toxic" (no number reported)
No number was reported for compound 4, and the estimate cannot be compared.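

Compound 3 and compound 4 are both entered without a number in this assay, so no step can be read between them. The compounds shown leave open at what concentration any of them turns cytotoxic, and compound 1 gives only a limit: the limit of > 50000 nM in this assay, at which 1 of the 4 values shown sits.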